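A few compounds are considered here, and "the series" means these few. Any claim that something is new, unique, unknown or untested is made for them only; others in the source may bear on it.

Measured so far in a functional assay on MDA-MB-231 cells (Homo sapiens) for antiproliferative activity, read by XTT assay, with a stated time of 72 h; a lower number here means a stronger inhibitor, a higher number a weaker inhibitor:
compound 1 `COc1ccc(-c2cc3ccccc3nc2/C=C/C(=O)c2ccc(F)cc2)cc1` gives 830 nM
compound 2 `COc1ccc(-c2cc3ccccc3nc2/C=C/C(=O)c2ccccn2)cc1` gives 740 nM

Compound 2 holds the lower of the two numbers, but the only step shown, a 1.1-fold lower number from compound 1 to compound 2 (0.05 log units; within the scatter), is within the scatter, so neither compound is separated from the other. Compound 3 `COc1ccc(-c2cc3ccccc3nc2/C=C/C(=O)c2ccc[nH]2)cc1` differs from compound 2 by 1H-pyrrol-2-yl in place of pyridin-2-yl on a carbonyl carbon. Among the compounds with values here, the one step that bears on this place, from a 4-fluorophenyl to a pyridin-2-yl group, moved the number hardly at all, so the ring on the carbonyl carbon has so far left this assay unchanged. No step beyond the scatter is therefore expected; the expected step is a 1.1-fold higher number from compound 2 to compound 3 (0.03 log units; within the scatter). Compound 3 is estimated at 800 nM, with a range from 350 nM to 1800 nM.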

Compound 3, half-maximal inhibitory concentration: > 10000 nM
Compound 3: only a limit was reported; the forecaster's own chance of this, stated with the estimate: 3%; middle value at least 12-fold (1.09 log units) from the limit.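

In this assay, the ring on the carbonyl carbon is not indifferent after all: 1H-pyrrol-2-yl gives an at least 13-fold higher number from compound 2 to compound 3 (1.13 log units; beyond the scatter) and an at least 12-fold higher number from compound 1 to compound 3 (1.08 log units; beyond the scatter). The 4-fluorophenyl and pyridin-2-yl groups, which the scatter does not separate, therefore do not speak for every ring at this place. Compound 3 gives > 10000 nM, which is a limit and not a number: the limit of > 10000 nM in this assay, at which 1 of the 3 values shown sits.

The five-membered ring and the hydrogen-bond donor enter together, and the compounds shown do not separate them. As far as these compounds go, whether a furan-2-yl or a 1-methyl-1H-pyrrol-2-yl group on this carbonyl carbon would behave like 1H-pyrrol-2-yl remains open.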